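The source may report more compounds than this note shows. Statements on the series, on what has been measured and on what is new or still open speak of the compounds shown alone.

Measured compounds:
compound 1, `O=C(/C=C/c1cn([C@H]2C[C@@H](C(=O)O)N(CCCc3ccccc3)C2)nn1)NO`: 29%
compound 2, `O=C(/C=C/c1cn([C@H]2C[C@H](CO)N(CCCc3ccccc3)C2)nn1)NO`: 16%
compound 3, `O=C(/C=C/c1cn([C@@H]2C[C@H](C(=O)O)N(CCCc3ccccc3)C2)nn1)NO`: 11%

In an assay on Sf9 cells for inhibition of histone deacetylase 11 (Homo sapiens), read by fluorescence, tested at 0.5 uM (on this read-out higher numbers stand for more inhibition at the one concentration tested (going by the name of the read-out) and lower numbers for less inhibition), compound 3 gives 11%, the lowest of the three numbers. Compound 2 gives 16%, which lies within the scatter of compound 3. Among the compounds with values here, compound 1 gives 29%; the step of a number 18 percentage points lower from compound 1 to compound 3 (beyond the scatter) is the only measured step in the set, and it rests on configuration alone because of the fact that compounds 1 and 3 differ only in the configuration as drawn.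

Compound 4, `O=C(/C=C/c1cn([C@H]2C[C@H](C(=O)O)N(CCCc3ccccc3)C2)nn1)NO`, is not yet measured. Against compound 3 the change is: the two compounds have the same atoms and bonds and differ only in configuration as drawn: 1 of 3 stereo elements differ; a stereocentre at a saturated ring carbon is drawn R in compound 3 and S in compound 4. Compound 4 thus carries one ring stereocentre as drawn in compound 3 and the other as drawn in compound 1, making it a diastereomer of both. Within the data shown here, the only measured step that bears on it is a number 18 percentage points lower from compound 1 to compound 3 (beyond the scatter), where both ring stereocentres were inverted together; no measured pair isolates the single inversion, so how much of that step belongs to this one centre is unknown. Among the measured compounds shown here, compound 2 differs in atoms and offers no step. The expected step is a number 9 percentage points higher from compound 3 to compound 4 (within the scatter), a rise that may not exceed the scatter. Compound 4 is estimated at 20% in this assay, range 8% to 34%.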

Compound 4, a percentage reported as inhibition, at one concentration (the size of the read-out at that concentration, not a potency): 20%
Compound 4: the middle estimate sits on the measured number at the digits printed, within the range that was stated.
By their numbers in this assay, from the lowest: compounds 3, 2, 4 and 1 (each within the scatter of the next, the first and the last beyond it).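

Each ring stereocentre can now be read alone in this assay: inverting one gives a number 9 percentage points higher from compound 3 to compound 4 (within the scatter), and inverting the other gives a number 9 percentage points lower from compound 1 to compound 4 (within the scatter). Within the data shown here, neither single inversion reaches beyond the scatter, while the paired inversion, a number 18 percentage points lower from compound 1 to compound 3 (beyond the scatter), does, so the earlier step cannot be assigned to either centre alone, and it appears only when both centres change: the fact that compounds 3 and 4 differ only in the configuration as drawn Carboxy in place of hydroxymethyl on a saturated ring carbon can also be read for the first time, as a number 4 percentage points higher from compound 2 to compound 4 (within the scatter), so at this one concentration the exchange is not resolved.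

Still open, from the compounds shown here alone, is whether the four stereo forms would separate as full potencies rather than as inhibition at one concentration, and whether the pattern seen with carboxy would hold for hydroxymethyl in the other configurations. Also open, going by these compounds, is how a methyl ester or a primary amide in place of carboxy on that ring carbon would read in this assay.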